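The compounds below may be only part of what the source reports. "The series", "measured", "known", "first", "only" and "open" are said of these compounds alone.

Among the measured compounds shown here, compound 1 `Cc1noc(NS(=O)(=O)c2cccc3c(NC(=O)C(C)C)cccc23)c1C` carries the lowest number among the three compounds measured so far in an assay on VSM-A10 cells for antagonist activity at Endothelin-1 receptor (Rattus norvegicus); on this read-out higher numbers stand for weaker inhibition and lower numbers for stronger inhibition. In this assay compound 1 gives 880 nM. Compound 2 `Cc1noc(NS(=O)(=O)c2ccc(NC(=O)CN)cc2)c1C` gives 6500 nM in this assay, a gap from compound 1 described as beyond the scatter. Compound 3 `Cc1noc(NS(=O)(=O)c2cccc([N+](=O)[O-])c2)c1C` gives 7800 nM in this assay, also beyond the scatter relative to compound 1. Compound 4 `Cc1noc(NS(=O)(=O)c2cccc3c(Cl)cccc23)c1C` has not yet been measured; it differs from compound 1 by chloro in place of (isopropylcarbonyl)amino on an aromatic carbon. For the measured compounds named here, no measured pair shows a step of this kind, so the direction is inferred from the compounds alone. The author expects the step of a 3.4-fold higher number from compound 1 to compound 4 (0.53 log units; beyond the scatter) to weaken inhibition beyond the scatter. Compound 4 is therefore estimated at 3000 nM, within 800 nM to 12000 nM.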

Compound 4, half-maximal inhibitory concentration: 24000 nM
Beside the measured number, compound 4's estimate is 8.0-fold (0.90 log units) below it, outside the stated range (above it).
By their numbers in this assay, from the lowest: compound 1; then compounds 2 and 3 (each within the scatter of the next); then compound 4.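

In this assay, chloro in place of (isopropylcarbonyl)amino on this aromatic carbon gives a 27-fold higher number from compound 1 to compound 4 (1.44 log units; beyond the scatter). This is the only pair shown that differs in one place, and it shows that inhibition depends strongly on what this carbon carries, with chloro not matching the (isopropylcarbonyl)amino group. Nothing available explains the size of this step. From the compounds shown here alone, it remains open which part of the (isopropylcarbonyl)amino group matters, the amide hydrogen, the carbonyl or the isopropyl end. Going by these compounds, how an amine or a longer chain on this carbon would compare also remains open.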